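Swapping a Chloropyrazine for a Chloropyrimidine Amide

The compounds below may be only part of what the source reports. "The series", "measured", "known", "first", "only" and "open" are said of these compounds alone.

Two anilides of the shared core have been tested in an assay on Jurkat cells for activation of nuclear factor NF-kappa-B complex (Homo sapiens); a higher number here means a weaker inhibitor, a lower number a stronger inhibitor. Compound 1 `Cc1nc(C(F)(F)F)ncc1C(=O)Nc1cc(C(F)(F)F)cc(C(F)(F)F)c1` only reaches a limit of the assay, recorded as > 10000 nM in this assay. For the measured compounds named here, compound 2 `O=C(Nc1cc(C(F)(F)F)cc(C(F)(F)F)c1)c1cnc(Cl)cn1` gives 4000 nM in this assay, the single real number in the set, the other entry being (the limit of > 10000 nM in this assay, at which 1 of the 2 values shown sits). Compound 3 `O=C(Nc1cc(C(F)(F)F)cc(C(F)(F)F)c1)c1cnc(Cl)nc1` holds the same atoms as compound 2, joined differently: 2-chloropyrimidin-5-yl in place of 5-chloropyrazin-2-yl on a carbonyl carbon. Going by the values given here, with no measured pair of this kind to lean on, a step within the usual scatter is expected, namely a 1.3-fold higher number from compound 2 to compound 3 (0.10 log units; within the scatter). Compound 3 is accordingly estimated at 5000 nM, with a range from 1500 nM to 20000 nM.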

Compound 3, half-maximal inhibitory concentration: 300 nM
Beside the measured number, compound 3's estimate is 17-fold (1.22 log units) above it; the whole stated range lies above it.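

In this assay the change to 2-chloropyrimidin-5-yl in place of 5-chloropyrazin-2-yl on a carbonyl carbon gives a 13-fold lower number from compound 2 to compound 3 (1.12 log units; beyond the scatter) although both groups hold the same atoms. For the compounds shown here, this position therefore responds to how the ring atoms are joined alone, which the earlier compounds, with no measured step between them, could not show. Nothing given here bears on the reason for this step. Still open, as far as these compounds go, is whether the chlorine of the 2-chloropyrimidin-5-yl group is needed, or whether an amine or a methoxy group there would keep the gain.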